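This account rests on a few compounds, and the source may have more. Where it says the series, first, only, none or still open, it means among the compounds named here.

In an assay (Rattus norvegicus) for inhibition of Fatty-acid amide hydrolase 1 (Homo sapiens) (on this read-out lower numbers stand for stronger inhibition and higher numbers for weaker inhibition), three compounds have been measured so far:

Compound 1 `O=C(CCCCCCc1ccccc1)c1ncc(-c2cccc(C(=O)C(F)(F)F)c2)o1`: 16 nM
Compound 2 `O=C(CCCCCCc1ccccc1)c1ncc(-c2ccc(O)cc2)o1`: 140 nM
Compound 3 `O=C(CCCCCCc1ccccc1)c1ncc(-c2cnc(C(=O)CCCCCCc3ccccc3)o2)o1`: 3500 nM

Compound 2 stands second highest of these three numbers. Its nearest neighbour is compound 1, whose number is lower by a margin beyond the scatter; furthest away is compound 3, whose number is higher, also beyond the scatter.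

Compound 4 `CN1CCN(C(=O)c2cnc(C(=O)CCCCCCc3ccccc3)o2)CC1` has not yet been measured in this assay. Against compound 2 the change is:

(4-methylpiperazin-1-yl)carbonyl in place of 4-hydroxyphenyl on an aromatic carbon

For the measured compounds named here, no pair of measured compounds differs in only one place, so no directly comparable step exists. What the numbers show is that the two compounds carrying a six-membered aromatic ring of carbon only on the shared core, compound 1 at 16 nM and compound 2 at 140 nM, sit at the low end, whereas compound 3 at 3500 nM, which carries a different group there, gives the highest number. The expected change is therefore a 4.3-fold higher number from compound 2 to compound 4 (0.63 log units; beyond the scatter), a higher number beyond the scatter. Compound 4 is estimated at 600 nM in this assay, between 120 nM and 3000 nM.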

Compound 4, inhibition constant: 80 nM
Beside the measured number, compound 4's estimate is 7.5-fold (0.88 log units) above it; measured number outside the range, below it.
By their numbers in this assay, from the lowest: compound 1; then compounds 4 and 2 (each within the scatter of the next); then compound 3.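

In this assay, putting (4-methylpiperazin-1-yl)carbonyl in place of 4-hydroxyphenyl on this aromatic carbon next to the ring oxygen gives a 1.8-fold lower number from compound 2 to compound 4 (0.24 log units; within the scatter), so the two groups cannot be told apart on this read-out. The group that enters has no hydrogen-bond donor and no six-membered aromatic ring of carbon only, so neither feature of 4-hydroxyphenyl is needed at this place for a number of this size. Nothing given here explains why two such different groups read alike.

From the compounds shown here alone, it remains open whether a carboxylic acid or a plain amine on this carbon would read the same way. Also open, going by these compounds, is whether the methyl on the piperazine matters, for which the unsubstituted piperazine or a morpholine carbonyl would be the comparison.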